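The source may hold more compounds than are shown below. What is called first, only, known or untested is meant among the compounds shown, and "the series" means these compounds.

Measured compounds:
Compound 1 `O=c1ccc2cc(OCc3cc(-c4cccc5ccccc45)no3)ccc2o1`: 47200 nM
Compound 2 `O=c1ccc2cc(OCc3cc(-c4ccc(Cl)cc4)no3)ccc2o1`: 44500 nM
Compound 3 `O=c1ccc2cc(OCc3cn(-c4ccccc4)nn3)ccc2o1`: 48800 nM

These three compounds were tested in a functional assay on COLO 205 cells (Homo sapiens) for cytotoxicity, read by MTT assay, with a stated time of 48 h; a higher number here means a weaker inhibitor, a lower number a stronger inhibitor. Compound 1 gives 47200 nM, compound 2 gives 44500 nM and compound 3 gives 48800 nM. The three numbers sit close together: the gaps between compound 3 and compound 1, and between compound 3 and compound 2, are both within the usual scatter of this assay, so nothing separates the three on these data.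

Compound 4 `O=c1ccc2cc(OCc3cn(-c4ccc([N+](=O)[O-])cc4)nn3)ccc2o1` has not yet been measured in this assay. It differs from compound 3 in one place: nitro in place of hydrogen on an aromatic carbon. Going by the values given here, no step between two measured compounds is available for this change, so there is no comparison to lean on. Given that compounds 1, 2 and 3 all sit within the scatter of one another, the expectation for compound 4 is a step of a 1.1-fold lower number from compound 3 to compound 4 (0.04 log units; within the scatter), which amounts to no change beyond the scatter. Compound 4 is therefore estimated at 45000 nM in this assay, with a range from 20000 nM to 100000 nM.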

Compound 4, half-maximal inhibitory concentration: 48700 nM
Compound 4: middle estimate off by 1.1-fold (0.03 log units), on the low side; the range from low to high includes it.
By their numbers in this assay, from the lowest: compounds 2, 1, 4 and 3 (each within the scatter of the next).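

In this assay, the move from phenyl to 4-nitrophenyl, on an aromatic carbon para to a large group, gives a 1.0-fold lower number from compound 3 to compound 4 (0.00 log units; within the scatter) and is the only step among these compounds that alters a single place. Going by these compounds alone, it shows that this position can carry nitro, with its 3 heavy atoms and 2 hydrogen-bond acceptors, and still give a number that cannot be told apart from that of the unsubstituted phenyl, something the earlier compounds, which differ in more than one place, could not show. Nothing available here bears on why the two numbers fall so close together.

As far as these compounds go, whether an amine or a carboxylic acid at the same position would give a number beyond the scatter of compound 3 remains open, as does the outcome of placing nitro on another carbon of that ring. With a single substituent tested at this position, the compounds shown also leave open whether any group placed there can separate itself from compound 3 at all.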